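Chain Length at One Aromatic Carbon: Isopropyl to Butyl

The source may hold more compounds than are shown below. What is called first, only, known or untested is meant among the compounds shown, and "the series" means these compounds.

Two measured compounds share one core and differ only in the group on one aromatic carbon. Compound 1 `CCCCCCCCc1cn([C@H]2C[C@@H]3OP(=O)(O)OC[C@H]3O2)c(=O)[nH]c1=O` carries an octyl chain, and in a functional assay on L1210 cells (Mus musculus) (a lower number here means a stronger inhibitor, a higher number a weaker inhibitor), compound 1 gives 193 ug/mL. Compound 2 `CC(C)c1cn([C@H]2C[C@@H]3OP(=O)(O)OC[C@H]3O2)c(=O)[nH]c1=O` carries an isopropyl group in its place. For compound 2 the result in this assay is only a limit, > 500 ug/mL; it sits at the limit of > 500 ug/mL in this assay, at which 1 of the 2 values shown sits. Going from the longer chain to the shorter, branched group, an at least 2.5-fold higher number from compound 1 to compound 2 (0.41 log units; beyond the scatter).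

Compound 3 `CCCCc1cn([C@H]2C[C@@H]3OP(=O)(O)OC[C@H]3O2)c(=O)[nH]c1=O` has not yet been measured. Its change from compound 2 is butyl in place of isopropyl on an aromatic carbon. The only measured step that bears on this is the one from octyl to isopropyl given above, which was at least modest and pointed toward a weaker inhibitor. Butyl lies between those two groups in length, so a number between the two earlier results seems likeliest, though since compound 2 stands only at a limit the size of the step cannot be fixed. The step expected here is an at least 1.2-fold lower number from compound 2 to compound 3 (0.09 log units; that floor lies within the scatter). In this assay compound 3 is estimated at 400 ug/mL, with a range from 200 ug/mL to 1000 ug/mL.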

Compound 3, concentration for 50% inhibition: 33.5 ug/mL
The estimate for compound 3 lay 12-fold (1.08 log units) above the measured number; measured number below the stated range.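

In this assay, putting butyl in place of isopropyl gives an at least 14-fold lower number from compound 2 to compound 3 (1.17 log units; beyond the scatter), so this aromatic carbon responds sharply to a small change in the group it carries. Shortening the chain from octyl to butyl also strengthens inhibition, with a 5.8-fold lower number from compound 1 to compound 3 (0.76 log units; beyond the scatter), which makes compound 3 the strongest inhibitor of the three and shows that the number does not simply follow chain length in one direction across these compounds. The step from compound 2 gives only a floor for the size of the change, since compound 2 stands at a limit: the limit of > 500 ug/mL in this assay, at which 1 of the 3 values shown sits.

Isopropyl and butyl differ in both length and branching, so these compounds cannot separate the two changes, and a straight propyl chain would be the direct comparison for telling them apart. As far as these compounds go, it also remains open where along the way from butyl to octyl inhibition begins to weaken, a point that a pentyl or hexyl chain could help to locate, and whether a chain carrying an amine or a carboxylic acid at its end would be tolerated here.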